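The source may hold more compounds than are shown below. What is called first, only, known or untested is meant among the compounds shown, and "the series" means these compounds.

In a functional assay on the whole organism with Mus musculus as the target, in the writhing test (a lower number here means that less compound is needed, a higher number that more compound is needed for the effect), two compounds have results so far. Compound 1 `FC(F)(F)CCCSc1nsnc1[C@@H]1CN2CCC[C@H]1C2` shows only a limit of the assay, > 10 mg/kg, rather than an exact number. Among the measured compounds shown here, compound 2 `CCCCSc1nccnc1C1CN2CCC1CC2` gives 3.2 mg/kg, which makes it the only compound here with an exact number. Compound 3 `CCCCCCSc1nccnc1C1CN2CCC1CC2` keeps the core of compound 2 and extends its chain on sulfur. The difference is ethyl in place of hydrogen on a saturated chain carbon, four bonds along the chain from a sulfur. For the measured compounds named here, no pair of measured compounds differs in just one place, so the data offer no direct guide to the size of this step. No shift beyond the usual scatter is therefore expected in this assay, although a move in either direction remains possible. The expected step is no change at the digits printed from compound 2 to compound 3 (within the scatter). For compound 3 the estimated value is 3.2 mg/kg, with an expected range of 1 mg/kg to 10 mg/kg.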

Compound 3, dose for half-maximal effect: 2.3 mg/kg
Compound 3: middle estimate off by 1.4-fold (0.14 log units), on the high side, within the range that was stated.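

In this assay, among the compounds shown here, the step gives the first direct reading at this position: ethyl in place of hydrogen on a saturated chain carbon, four bonds along the chain from a sulfur, gives a 1.4-fold lower number from compound 2 to compound 3 (0.14 log units; within the scatter). The chain on sulfur can therefore take these two extra carbons with no shift beyond the usual scatter, at least for this one extension. Both compounds give exact numbers, and the only limit shown belongs to compound 1, which differs from them in more than one place: the limit of > 10 mg/kg in this assay, at which 1 of the 3 values shown sits.

As far as these compounds go, whether the value would hold with a longer chain, or with a chain ending in an amine or a carboxylic acid, remains open. The compounds shown also do not tell why this added ethyl leaves the value within the scatter.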